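Aryl swap on the shared core: compound 2 to compound 3

A few compounds are considered here, and "the series" means these few. Any claim that something is new, unique, unknown or untested is made for them only; others in the source may bear on it.

Within the two compounds measured in a functional assay on NCI-H226 cells (Homo sapiens) for inhibition, read by sulforhodamine B assay, with a stated time of 48 h, tested at 10 uM (a lower number here means less inhibition, a higher number more inhibition at the concentration tested (going by the name of the read-out)), compound 2 `c1ccc2c(-c3cn4ccnc4c(-c4ccc5ncn(C6CCCCC6)c5c4)n3)cccc2c1` stands lowest: it gives 9.45%, while compound 1 `c1ccc(-c2cn3ccnc3c(-c3ccc4ncn(C5CCCCC5)c4c3)n2)cc1` gives 33.9%. Among the compounds with values here, the single step between them, a number 24.5 percentage points lower from compound 1 to compound 2 (beyond the scatter), is the only measured step in the set and the one that bears on what follows.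

Compound 3 `Fc1ccc(-c2cn3ccnc3c(-c3ccc4ncn(C5CCCCC5)c4c3)n2)cc1` is not yet measured. Its structure differs from compound 2 by 4-fluorophenyl in place of naphthalen-1-yl on an aromatic carbon, on an aromatic carbon. Within the data shown here, the one step on record went from phenyl to naphthalen-1-yl and lowered the read-out; the move to compound 3 reverses that direction, back to a single six-membered aromatic ring of carbon only, now carrying a fluorine. Among the measured compounds shown here, no measured pair shows what the fluorine alone does, so the expectation rests on compound 1 as the nearest measured neighbour in structure.

The step is therefore expected to run upward, roughly undoing the earlier drop, by a number 20.6 percentage points higher from compound 2 to compound 3 (beyond the scatter). The value of compound 3 in this assay is estimated at 30%, with a range of 10% to 50%.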

Compound 3, a percentage reported as inhibition, at one concentration (the size of the read-out at that concentration, not a potency): 23.3%
Beside the measured number, compound 3's estimate is 6.7 percentage points above it; low and high end bracket the measured number.
By their numbers in this assay, from the lowest: compound 2; then compound 3; then compound 1.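

In this assay, three groups can now be compared at this aromatic carbon of the shared core, and phenyl in compound 1 stays above both replacements, with each gap beyond the scatter. The new fluoro pair adds what the earlier naphthalen-1-yl step could not show: fluoro in place of hydrogen on the phenyl ring gives a number 10.6 percentage points lower from compound 1 to compound 3 (beyond the scatter), so a change of one atom on this ring is enough to shift the read-out. Going from naphthalen-1-yl to 4-fluorophenyl gives a number 13.9 percentage points higher from compound 2 to compound 3 (beyond the scatter), so a return to one six-membered aromatic ring of carbon only recovers part of the earlier drop, but not all of it, and no measurement here gives a reason for this order.

The compounds shown leave open whether the lower read-out belongs to fluoro specifically or would also follow from other groups on the phenyl ring, such as methoxy, an amine or a carboxylic acid. They also leave open how a pyridine ring would read at this carbon, and, with a single tested concentration, how the three compounds would rank by potency.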